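The source may report more compounds than this note shows. Statements on the series, on what has been measured and on what is new or still open speak of the compounds shown alone.

Compound 1 `COc1cccc(-c2c(C)n(Cc3c(F)cccc3F)c(=O)n(C[C@H](N)CC(C)C)c2=O)c1F` is the stronger of the two measured entries: in an assay on HEK293 cells for binding affinity to Gonadotropin-releasing hormone receptor (Homo sapiens), read by radioligand binding (on this read-out higher numbers stand for weaker inhibition and lower numbers for stronger inhibition), compound 1 gives 6.4 nM, the lower of the two numbers. Within the data shown here, compound 2 `COc1cccc(-c2c(C)n(Cc3c(F)cccc3F)c(=O)n(C[C@H](N)C(C)C)c2=O)c1F` gives 51 nM in this assay, and the single one-place step available, an 8.0-fold higher number from compound 1 to compound 2 (0.90 log units; beyond the scatter), shows that shortening the side chain on the carbon that carries the amine costs affinity beyond the scatter.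

Compound 3 `COc1cccc(-c2c(C)n(Cc3c(F)cccc3F)c(=O)n(C[C@@H](C3CCCCC3)N(C)C)c2=O)c1F` differs from compound 1 by cyclohexyl(dimethylamino)methyl in place of 1-amino-3-methylbutyl on a saturated chain carbon bound to an aromatic nitrogen. The change bundles two things: the chain on the amine-bearing carbon becomes a cyclohexyl ring, and the amine loses its hydrogen-bond donor as it becomes dimethylamino. Among the measured compounds shown here, only the step from compound 1 to compound 2 bears on the first part, and it points toward a weaker number when that carbon is more branched. Nothing measured covers the second part.

The expectation is therefore a loss relative to compound 1, with a step of about a 6.3-fold higher number from compound 1 to compound 3 (0.80 log units; beyond the scatter), since compound 2 already showed an 8.0-fold higher number from compound 1 to compound 2 (0.90 log units; beyond the scatter) for a smaller change at that carbon. Compound 3 is estimated at 40 nM in this assay, within a range of 8 nM to 200 nM.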

Compound 3, inhibition constant: 4.1 nM
Beside the measured number, compound 3's estimate is 9.8-fold (0.99 log units) above it, and the stated range ends above it.
By their numbers in this assay, from the lowest: compounds 3 and 1 (each within the scatter of the next); then compound 2.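

In this assay, cyclohexyl(dimethylamino)methyl in place of 1-amino-3-methylbutyl gives a 1.6-fold lower number from compound 1 to compound 3 (0.19 log units; within the scatter), so on this saturated chain carbon bound to an aromatic nitrogen, a larger group with a six-membered carbon ring and no hydrogen-bond donor is accommodated with no readable change in the number. The same group in place of the 1-amino-2-methylpropyl of compound 2 gives a 12-fold lower number from compound 2 to compound 3 (1.09 log units; beyond the scatter), so the earlier loss at the amine-bearing carbon does not carry over to every branched group there, and compound 3 goes against any such reading. No supporting data bear on the reason for these numbers.

The cyclohexyl ring and the dimethylamino group enter together, so the compounds shown leave their separate contributions open, including whether the ring would read the same with a free amine or the 1-amino-3-methylbutyl chain with a dimethylamino group. On these data alone, how a phenyl ring on that carbon, or a methylamino group or carboxylic acid in place of the amine, would read in this assay also remains open.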